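Swapping a Chain Hydroxy for Methyl: Cytotoxicity Outlook

The source may hold more compounds than are shown below. What is called first, only, known or untested is meant among the compounds shown, and "the series" means these compounds.

Two compounds have so far been characterised in an ADME assay on Huh-7 cells (Homo sapiens) for cytotoxicity; a higher number here means that more compound is tolerated, a lower number that less compound is tolerated. Compound 1 `Cc1ccc(-c2nn(-c3ccc(F)cc3F)cc2CNCCN2CCN(C)CC2)cc1` reaches only the limit of the assay, reported as > 20000 nM. Compound 2 `Cc1ccccc1-c1nn(-c2ccc(F)cc2F)cc1CNCCCCO` likewise yields a limit rather than a number, > 20000 nM. Compound 2 therefore stands exactly where everything measured here stands, at the limit of > 20000 nM in this assay, at which 2 of the 2 values shown sit, with no measured value to rank it against.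

Compound 3 `CCCCCNCc1cn(-c2ccc(F)cc2F)nc1-c1ccccc1C` remains to be tested in this assay. It differs from compound 2 by methyl in place of hydroxy on a saturated chain carbon, four bonds along the chain from an amine nitrogen. For the measured compounds named here, no step between two measured compounds exists to calibrate this change, so the expectation rests on the limits alone: both compounds measured so far sit at the ceiling of the assay, and the expected step is a step that the limit leaves unreadable from compound 2 to compound 3, meaning none beyond the scatter and nothing anticipated to pull the new compound down into the measurable range. In this assay compound 3 is estimated at 25000 nM, with a range from 8000 nM to 60000 nM, and is most likely to be reported once more as a limit.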

Compound 3, half-maximal cytotoxic concentration: 17000 nM
Compound 3: middle estimate off by 1.5-fold (0.17 log units), on the high side, within the range that was stated.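

In this assay, for the compounds shown here, compound 3 gives 17000 nM, the first value in this small set that is a number and not a limit, so the change on a saturated chain carbon, four bonds along the chain from an amine nitrogen, now has one readable end. Methyl in place of hydroxy at this place comes with an at least 1.1-fold lower number from compound 2 to compound 3 (0.07 log units; that floor lies within the scatter), which sets a floor for the step but not its size. The true size stays unknown because compound 2 is known only as a limit of the assay: the limit of > 20000 nM in this assay, at which 2 of the 3 values shown sit.

The compounds shown leave open how large the step from hydroxy to methyl really is, and whether it would hold on another chain or with another group on the shared core. They also do not tell how an amine or a carboxylic acid at this place on the chain, or a longer chain ending in methyl, would stand in this assay.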